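The source may report more compounds than this note shows. Statements on the series, on what has been measured and on what is new or still open speak of the compounds shown alone.

In a functional assay on A549 cells (Homo sapiens) for antiproliferative activity, with a stated time of 5 days (on this read-out lower numbers stand for stronger inhibition and higher numbers for weaker inhibition), compound 1 `COc1ccc(-n2nc(-c3ccc4ccccc4c3)nc2N2C(=O)COC23C=CC(=O)C=C3)cc1` gives 260 nM. Two relatives have been measured alongside it: compound 2 `CC1CN(c2nc(-c3ccc4ccccc4c3)nn2-c2ccccc2)C2(C=CC(=O)C=C2)O1` gives 320 nM, and compound 3 `CC1OC2(C=CC(=O)C=C2)N(c2nc(-c3cccc4ccccc34)nn2-c2ccccc2)C1=O` gives 180 nM. Compound 1 has the middle number of the three, but all three values lie within the usual scatter of one another, so no order among them can be claimed.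

Compound 4 `COc1ccc(-n2nc(-c3ccc4ccccc4c3)nc2N2C(=O)C(C)OC23C=CC(=O)C=C3)cc1` is compound 1 with a single change: methyl in place of hydrogen on a saturated ring carbon. Among the measured compounds shown here, no measured pair shows this change alone. Compound 2 and compound 3 do carry a methyl on such a carbon, but both differ from compound 1 in other places too, so they offer only a rough guide. Even so, compound 3, at 180 nM, stays within the scatter of compound 1, which gives no reason to expect a large shift. The expected step is a 1.2-fold lower number from compound 1 to compound 4 (0.07 log units; within the scatter), which would not go beyond the scatter. For compound 4 the estimated value is 220 nM, with an expected range of 100 nM to 480 nM.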

Compound 4, half-maximal inhibitory concentration: 860 nM
For compound 4 the middle estimate is 3.9-fold (0.59 log units) below the measured one; the measured number lies above the stated range.
By their numbers in this assay, from the lowest: compounds 3, 1 and 2 (each within the scatter of the next); then compound 4.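

In this assay, methyl in place of hydrogen on a saturated ring carbon, with nothing else changed, brings a 3.3-fold higher number from compound 1 to compound 4 (0.52 log units; beyond the scatter), which means weaker inhibition. The earlier compounds shown here could not isolate this change, but this pair shows that the position, next to the ring oxygen, is sensitive to even one added carbon. No measurement shown here gives a reason for this step.

As far as these compounds go, it remains open whether any group at this carbon would bring a similar step, or whether the result is particular to methyl; an ethyl group, a hydroxymethyl group or a fluorine atom there would help to separate these possibilities. Among the compounds shown here, it is also unknown whether methyl has the same effect when the rest of the molecule differs, as no single-change pair tests it on another core.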